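Swapping an Isopropyl for a Furan Ring on a Side Chain

The source may report more compounds than this note shows. Statements on the series, on what has been measured and on what is new or still open speak of the compounds shown alone.

Measured so far:
compound 1 `CCN(C1=NCCN1)c1c(Br)cccc1Br`: -1.01
compound 2 `CC(C)CN(C1=NCCN1)c1c(Br)cccc1Br`: -0.64
compound 3 `C=CCCN(C1=NCCN1)c1c(Br)cccc1Br`: -0.63

Three compounds share one core and differ only in the chain carried by the nitrogen on the aromatic ring. In a physicochemical assay for lipophilicity (on this read-out lower numbers stand for lower lipophilicity and higher numbers for higher lipophilicity), compound 1 gives -1.01. Going a number 0.37 log units higher from compound 1 to compound 2 (beyond the scatter) and going a number 0.38 log units higher from compound 1 to compound 3 (beyond the scatter) both add a branch to that chain. Compound 2 stands second highest of the three; the step of a number 0.01 log units higher from compound 2 to compound 3 (within the scatter) is within the scatter, so compound 2 and compound 3 cannot be told apart, and compound 1 alone sits clearly lower.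

Compound 4 `Brc1cccc(Br)c1N(Cc1ccco1)C1=NCCN1` is not yet measured. Its difference from compound 2 is furan-2-yl in place of isopropyl on a saturated chain carbon bound to a nitrogen on an aromatic ring. Both earlier steps on this chain carbon concerned small saturated or unsaturated carbon groups, none of them a ring with an oxygen, so they give only a loose guide: they show that changing this chain moves the read-out by modest amounts. The entering group brings one hydrogen-bond acceptor where the leaving isopropyl had none. A small downward step is expected, a number 0.26 log units lower from compound 2 to compound 4 (within the scatter), possibly no larger than the scatter. Compound 4 is therefore estimated at -0.9, within -1.4 to -0.4.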

Compound 4, distribution coefficient: -0.52
The estimate for compound 4 lay 0.38 log units below the measured number; the range from low to high includes it.
By their numbers in this assay, from the lowest: compound 1; then compounds 2, 3 and 4 (each within the scatter of the next).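

Going by these compounds alone, the step of a number 0.12 log units higher from compound 2 to compound 4 (within the scatter) and the step of a number 0.11 log units higher from compound 3 to compound 4 (within the scatter) show that, in this assay, furan-2-yl cannot be told apart from isopropyl or allyl on this saturated chain carbon, even though it is the first group here to bring a ring and a hydrogen-bond acceptor. The step of a number 0.49 log units higher from compound 1 to compound 4 (beyond the scatter) places it, like those two open-chain groups, clearly above methyl, so across these four compounds, having a hydrogen-bond acceptor in the entering group does not bring the number back towards the low end. No measurement shown here accounts for why the ring and its oxygen leave no visible mark on the read-out.

From the compounds shown here alone, it remains open whether an amine or a carboxylic acid at this place would separate clearly from the three groups that cannot be told apart. A longer chain, or a five-membered aromatic ring set further out along the chain, is equally untested by the compounds shown, so how far this flat stretch of values extends cannot be said.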